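The source may report more compounds than this note shows. Statements on the series, on what has been measured and on what is new or still open speak of the compounds shown alone.

Working notes on the series. In a functional assay on A549 cells (Homo sapiens) for inhibition, read by sulforhodamine B assay (on this read-out higher numbers stand for weaker inhibition of growth and lower numbers for stronger inhibition of growth), compound 1 (`c1ccc(-c2ccc(-c3ccc(-c4nc5ccccc5[nH]4)cc3)cc2)cc1`) gives 41200 nM and compound 3 (`FC(F)(F)Oc1ccc(-c2ccc(-c3ccc(-c4nc5ccccc5[nH]4)cc3)cc2)cc1`) gives 38000 nM. Compound 3 thus sits with compound 1 at the high end of the three numbers. The number for compound 2 (`Cc1ccc2[nH]c(-c3ccc(-c4ccc(-c5ccc(N(C)C)cc5)cc4)cc3)nc2c1`) is well lower than both of these: compound 2 gives 3510 nM.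

Compound 4 (`CN(C)c1ccc(-c2ccc(-c3ccc(-c4nc5ccccc5[nH]4)cc3)cc2)cc1`) has dimethylamino in place of the trifluoromethoxy of compound 3, on an aromatic carbon para to a large group: dimethylamino in place of trifluoromethoxy on an aromatic carbon. Within the data shown here, one measured step touches this place: a 1.1-fold lower number from compound 1 to compound 3 (0.04 log units; within the scatter), which lies within the scatter and says little about dimethylamino. The closer evidence is compound 2, which also carries dimethylamino, plus a methyl on the shared core, at 3510 nM. Among the measured compounds shown here, no measured step separates what the methyl and the dimethylamino each contribute, so only part of that gap is expected to carry over to compound 4. A lower number than for compound 3 is expected in this assay, beyond the scatter but probably not reaching the level of compound 2. The estimated step is a 4.2-fold lower number from compound 3 to compound 4 (0.63 log units; beyond the scatter). For compound 4 the estimated value is 9000 nM, with an expected range from 3000 nM to 30000 nM.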

Compound 4, concentration for 50% growth inhibition: 30100 nM
Compound 4: middle estimate off by 3.3-fold (0.52 log units), on the low side; measured number outside the range, above it.
By their numbers in this assay, from the lowest: compound 2; then compounds 4, 3 and 1 (each within the scatter of the next).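

In this assay, this aromatic carbon para to a large group now has a direct reading for dimethylamino: a 1.3-fold lower number from compound 3 to compound 4 (0.10 log units; within the scatter) and a 1.4-fold lower number from compound 1 to compound 4 (0.14 log units; within the scatter), so both steps leave dimethylamino, trifluoromethoxy and hydrogen at this place within the scatter of one another. Among these compounds, with dimethylamino held in place, hydrogen in place of the methyl on the shared core gives an 8.6-fold higher number from compound 2 to compound 4 (0.93 log units; beyond the scatter), the only new step beyond the scatter, which ties the low number of compound 2 to that methyl in this pair rather than to dimethylamino alone. No accompanying measurement bears on why the number responds to this methyl and not to the change at the other place.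

Methyl on the shared core appears here only together with dimethylamino, so it remains open whether the same methyl would give a step of this size with hydrogen or trifluoromethoxy at the other place. As far as these compounds go, it also remains open whether a carboxylic acid or a primary amine on this aromatic carbon would move the number beyond the scatter of compound 1, compound 3 and compound 4.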